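Exchanging one aromatic ring on a shared core

This account rests on a few compounds, and the source may have more. Where it says the series, first, only, none or still open, it means among the compounds named here.

In an ADME assay on microsomes (Homo sapiens) for metabolic stability (on this read-out lower numbers stand for slow clearance and higher numbers for fast clearance), compound 1 `CNC(=O)[C@@H]1CCCN1S(=O)(=O)c1ccc(Cl)c(COc2cccc3c(-c4ccccn4)cc(C)nc23)c1Cl` gives 183 mL/min/kg, compound 2 `CNC(=O)[C@@H]1CCCN1S(=O)(=O)c1ccc(Cl)c(COc2cccc3c(-c4ccncc4)cc(C)nc23)c1Cl` gives 217 mL/min/kg and compound 3 `CNC(=O)[C@@H]1CCCN1S(=O)(=O)c1ccc(Cl)c(COc2cccc3c(-c4ccncc4)cc(C(C)C)nc23)c1Cl` gives 333 mL/min/kg. These three numbers lie within the usual scatter of one another, so compound 3 does not stand apart from the other two. The next structure, compound 4 `CNC(=O)[C@@H]1CCCN1S(=O)(=O)c1ccc(Cl)c(COc2cccc3c(-c4cncn4C)cc(C(C)C)nc23)c1Cl`, keeps the shared core and the isopropyl group of compound 3 but has 1-methyl-1H-imidazol-5-yl in place of pyridin-4-yl on an aromatic carbon, opposite the ring nitrogen: 1-methyl-1H-imidazol-5-yl in place of pyridin-4-yl on an aromatic carbon. Two measured steps offer some guidance. Pyridin-4-yl in place of pyridin-2-yl gave a 1.2-fold higher number from compound 1 to compound 2 (0.07 log units; within the scatter), and isopropyl in place of methyl gave a 1.5-fold higher number from compound 2 to compound 3 (0.19 log units; within the scatter). Both are small, but neither tests a five-membered ring, so the data give no firm direction for this exchange. The estimated step is a 1.2-fold lower number from compound 3 to compound 4 (0.08 log units; within the scatter), which is not expected to exceed the scatter. For compound 4 the expected value is 280 mL/min/kg, with an estimated range from 140 mL/min/kg to 500 mL/min/kg.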

Compound 4, clearance: 33.3 mL/min/kg
Compound 4: the middle estimate sits 8.4-fold (0.92 log units) above what was measured; the measured number lies below the stated range.
By their numbers in this assay, from the lowest: compound 4; then compounds 1, 2 and 3 (each within the scatter of the next).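

In this assay, 1-methyl-1H-imidazol-5-yl in place of pyridin-4-yl gives a 10-fold lower number from compound 3 to compound 4 (1.00 log units; beyond the scatter), the only step among these compounds that lies beyond the scatter. The earlier exchange at this position, pyridin-4-yl in place of pyridin-2-yl, gave a 1.2-fold higher number from compound 1 to compound 2 (0.07 log units; within the scatter), which is within the scatter, so only now is it clear that the group opposite the ring nitrogen can strongly change this number when a five-membered ring replaces a six-membered one. No available measurement explains why the number falls so far with this ring.

The compounds shown cannot separate the roles of ring size, the second ring nitrogen and the methyl group on the ring, which a 1H-imidazol-5-yl group without that methyl or a 1-methyl-1H-pyrazol-5-yl group could help to tell apart. Going by these compounds, it also remains open whether the same exchange would have a similar effect with methyl in place of isopropyl.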